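This account rests on a few compounds, and the source may have more. Where it says the series, first, only, none or still open, it means among the compounds named here.

Measured compounds:
Compound 1 `COc1cc2c(c(O)c1C(=O)/C=C/c1ccc(OC(=O)c3cccc(Cl)c3)cc1)CCC(C)(C)O2` — in an assay on HEK293T cells for inhibition of nuclear factor NF-kappa-B complex (Homo sapiens), read by a luciferase reporter (a higher number here means a weaker inhibitor, a lower number a stronger inhibitor), compound 1 gives > 30000 nM, which is a limit of the assay rather than a number.
Compound 2 `CCCCC(=O)Oc1ccc(/C=C/C(=O)c2c(OC)cc3c(c2O)CCC(C)(C)O3)cc1` — in this assay compound 2 gives > 30000 nM, again only a limit.

Both measured compounds sit where the assay stops reading, as the limit of > 30000 nM in this assay, at which 2 of the 2 values shown sit, shows. For the measured compounds named here, the one measured step, a step that the two limits leave unreadable from compound 1 to compound 2, therefore cannot be given a size, and compound 2 stands at that same edge with no number of its own. Compound 3 `COc1cc2c(c(O)c1C(=O)/C=C/c1ccc(OC(C)=O)cc1)CCC(C)(C)O2` differs from compound 2 by hydrogen in place of propyl on a saturated chain carbon bound to a carbonyl carbon. Going by the values given here, the only measured step that touches this part of the molecule is the unreadable one, so no size and no direction can be taken from it. Compound 3 is expected to remain at the edge of the assay, with a step that the limit leaves unreadable from compound 2 to compound 3 that is estimated from the limit alone. The estimate for compound 3 is 40000 nM, within 15000 nM to 150000 nM.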

Compound 3, half-maximal inhibitory concentration: > 30000 nM
Compound 3 gave a limit, no number; the forecaster's own chance of this, stated with the estimate: 75%; the middle value does not contradict the limit.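

The steps from compound 1 and compound 2 to compound 3 cannot be read, because all three compounds sit at the same limit: the limit of > 30000 nM in this assay, at which 3 of the 3 values shown sit. The compounds shown leave open how strong each of them really is, and whether any group on this carbonyl carbon gives a readable number.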